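A few compounds are considered here, and "the series" means these few. Any claim that something is new, unique, unknown or untested is made for them only; others in the source may bear on it.

Measured compounds:
compound 1 `Nc1scc(CN2CCN(c3cccc(Cl)c3Cl)CC2)c1C(=O)c1ccc(Cl)cc1` — 3.2%
compound 2 `Nc1scc(CN2CCN(c3ccc(Cl)cc3F)CC2)c1C(=O)c1ccc(Cl)cc1` — -9.4%
compound 3 `Nc1scc(CN2CCN(c3ccccc3F)CC2)c1C(=O)c1ccc(Cl)cc1` — -1%

All three share one core and differ only in the aryl group on the amine nitrogen in the ring. In a functional assay on CHO cells with adenosine receptor A1 (Homo sapiens) as the target, read by cAMP accumulation and immunoassay, with a stated time of 6 min, tested at 0.1 uM (on this read-out higher numbers stand for a weaker effect at the one concentration tested and lower numbers for a stronger effect), the three numbers sit close together at the single concentration tested. Compound 3 is nearest to compound 1, with a number 4.2 percentage points lower from compound 1 to compound 3 (within the scatter), and furthest from compound 2, with a number 8.4 percentage points higher from compound 2 to compound 3 (within the scatter); neither gap is beyond the scatter. Among the compounds with values here, the one step that does clear the scatter is a number 12.6 percentage points lower from compound 1 to compound 2 (beyond the scatter), and even that is modest.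

Compound 4 `Nc1scc(CN2CCN(CCCc3ccc(Cl)cc3)CC2)c1C(=O)c1ccc(Cl)cc1` is not yet measured. It differs from compound 3 as follows: 3-(4-chlorophenyl)propyl in place of 2-fluorophenyl on an amine nitrogen in a ring. Within the data shown here, every measured step swaps one aryl ring for another at the same nitrogen; none replaces the ring with a 3-(4-chlorophenyl)propyl chain, so no step bears directly on this change. What the series does show is that three different aryl groups at this position all give numbers within a narrow band, with only a number 12.6 percentage points lower from compound 1 to compound 2 (beyond the scatter) beyond the scatter. On that basis no step beyond the scatter is expected for compound 4, so the expected change is no change at the digits printed from compound 3 to compound 4 (within the scatter). The estimate for compound 4 in this assay is -1%, with a range from -15% to 13%.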

Compound 4, a percentage reported as activity, at one concentration (the size of the read-out at that concentration, not a potency): -3%
The estimate for compound 4 lay 2 percentage points above the measured number, within the range that was stated.
By their numbers in this assay, from the lowest: compounds 2, 4, 3 and 1 (each within the scatter of the next, the first and the last beyond it).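

In this assay, moving from aryl groups set directly on the amine nitrogen in a ring to 3-(4-chlorophenyl)propyl opens no step beyond the scatter, with a number 2 percentage points lower from compound 3 to compound 4 (within the scatter) and a number 6.4 percentage points higher from compound 2 to compound 4 (within the scatter) and a number 6.2 percentage points lower from compound 1 to compound 4 (within the scatter) all printed as within it. The position therefore accepts more than a directly attached aryl ring: the entering group has 10 heavy atoms against 7 for the 2-fluorophenyl it replaces, and its six-membered aromatic ring sits at the end of a propyl chain, yet the read-out stays in the same narrow band at this one concentration. Within the data shown here, the only gap beyond the scatter is still the one between compound 1 and compound 2, and no measurement at hand gives a reason for this flat response at the position.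

Open, on these data alone, is whether a shorter or longer chain than propyl, or a chain ending in an amine or a carboxylic acid in place of the 4-chlorophenyl ring, would stay within this band. Also open, as far as these compounds go, is whether compounds that match at this one concentration would also match across a full concentration range.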